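This account rests on a few compounds, and the source may have more. Where it says the series, first, only, none or still open, it means among the compounds named here.

In a functional assay on HeLa cells (Homo sapiens) for antiproliferative activity, read by MTT assay, with a stated time of 48 h (on this read-out lower numbers stand for stronger inhibition and higher numbers for weaker inhibition), compound 1 (`Clc1ccccc1CSc1nnc(-c2cnccn2)o1`) gives 23000 nM and compound 2 (`Clc1ccccc1CSc1nnc(-c2cnccn2)s1`) gives 28900 nM, two values within the usual scatter of each other. In this assay compound 3 (`Brc1ccccc1CSc1nnc(-c2cnccn2)n1-c1ccccc1`) gives > 50000 nM, which is a limit of the assay and not a number. So compound 3 has no exact reading, and its true value remains unknown.

Compound 4 (`c1ccc(CSc2nnc(-c3cnccn3)n2-c2ccccc2)cc1`) differs from compound 3 in one place: hydrogen in place of bromo on an aromatic carbon. It has hydrogen in place of bromo on an aromatic carbon, ortho to a large group, so 2-bromobenzyl becomes benzyl. Among the measured compounds shown here, no measured pair here shows what this exchange does, so no step beyond the scatter is expected in this assay, and no direction is favoured. For the measured compounds named here, this expectation rests on compound 3, whose limit of > 50000 nM is the only reading for the structure nearest to the new one. The expected step is a number no higher from compound 3 to compound 4 (the limit leaves the size open). For compound 4 the estimated value is 50000 nM, within an expected range from 25000 nM to 100000 nM.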

Compound 4, half-maximal inhibitory concentration: 35600 nM
For compound 4 the middle estimate is 1.4-fold (0.15 log units) above the measured one; low and high end bracket the measured number.
By their numbers in this assay, from the lowest: compounds 1, 2 and 4 (each within the scatter of the next). At a limit, above all of these: compound 3.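

In this assay, the exchange of 2-bromobenzyl for benzyl gives an at least 1.4-fold lower number from compound 3 to compound 4 (0.14 log units; that floor lies within the scatter). On these data alone, the reading for compound 3 is a limit of the assay, so only the floor of this step is known and its true size stays open: the limit of > 50000 nM in this assay, at which 1 of the 4 values shown sits. What compound 4 adds is an exact number for this structure, since with hydrogen on this aromatic carbon compound 4 gives 35600 nM, which shows that the bromo is not needed for a measurable reading on these cells.

The compounds shown leave open what a fluoro, a methyl or a methoxy group would do in place of that hydrogen. They also leave open whether removing the halogen from the benzyl group would have a similar outcome on the core of compound 1 or of compound 2.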